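Replacing hydroxy with amino on compound 2

A few compounds are considered here, and "the series" means these few. Any claim that something is new, unique, unknown or untested is made for them only; others in the source may bear on it.

Within the data shown here, in a functional assay on A2780 cells (Homo sapiens) for antiproliferative activity, read by MTT assay, with a stated time of 48 h (on this read-out higher numbers stand for weaker inhibition and lower numbers for stronger inhibition), compound 1 (`COc1ccc(C(=O)c2ccc3c(c2)C=CC(C)(C)O3)c(NC(=O)CBr)c1`) gives 1870 nM and compound 2 (`C=C(c1ccc2c(c1)C=CC(C)(C)O2)c1ccc(OC)cc1NC(=O)CO`) gives 110 nM as the lower of the two numbers so far, with a gap beyond the scatter. These two structures differ in more than one place, so their gap does not isolate any single change. Compound 3 (`C=C(c1ccc2c(c1)C=CC(C)(C)O2)c1ccc(OC)cc1NC(=O)CN`) has not yet been measured. It departs from compound 2 by amino in place of hydroxy on a saturated chain carbon bound to a carbonyl carbon and thus carries amino in place of hydroxy on a saturated chain carbon bound to a carbonyl carbon. Among the measured compounds shown here, no measured pair tests this exchange, so the expectation is anchored on compound 2 at 110 nM alone. The expected result in this assay is a 1.1-fold lower number from compound 2 to compound 3 (0.04 log units; within the scatter) and no change beyond the scatter in either direction is expected. For compound 3 the estimate is 100 nM with an expected range from 30 nM to 350 nM in this assay.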

Compound 3, half-maximal inhibitory concentration: 140 nM
Estimate against measurement, compound 3: 1.4-fold (0.15 log units) below, within the range that was stated.
By their numbers in this assay, from the lowest: compounds 2 and 3 (each within the scatter of the next); then compound 1.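

In this assay, among these compounds, amino in place of hydroxy on a saturated chain carbon bound to a carbonyl carbon gives a 1.3-fold higher number from compound 2 to compound 3 (0.10 log units; within the scatter), the first comparison that isolates a single change. This read-out therefore does not separate hydroxy from amino at this place, an exchange that leaves the counts of heavy atoms, hydrogen-bond donors and hydrogen-bond acceptors unchanged and adds no net charge. No supporting evidence bears on the reason for this result.

The compounds shown leave open how a dimethylamino group, a carboxylic acid or a longer chain carrying the amine would read at this place. Compound 1 differs from compound 2 in more than one place, so its gap remains unassigned to any single change.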